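This account rests on a few compounds, and the source may have more. Where it says the series, first, only, none or still open, it means among the compounds named here.

Compound 1, `COc1cc(-c2ccc(O)cc2O)nc2ccccc12`, in a functional assay on HT-22 cells (Mus musculus), read by MTT assay, with a stated time of 24 h (a higher number here means that more compound is needed for the effect, a lower number that less compound is needed), gives only a limit, > 500 nM; (the limit of > 500 nM in this assay, at which 1 of the 3 values shown sits). Compound 2, `CC(C)Oc1cc(-c2ccc(O)cc2O)nc2ccccc12`, gives 210 nM. Compound 3, `COc1cc(-c2ccc(N(C)C)cc2)nc2ccccc12`, gives 60 nM.

From compound 1 to compound 2 the change is isopropyl in place of methyl on an oxygen on an aromatic ring, and it brought an at least 2.3-fold lower number from compound 1 to compound 2 (0.37 log units; beyond the scatter), a step that starts from a limit. Compound 3 stands on a different core; how its core differs from that of compound 1 is not broken down here. Compound 3 gives the lowest number of the three, and its value is lower than that of compound 2.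

Compound 4, `CC(C)Oc1cc(-c2ccc(N(C)C)cc2)nc2ccccc12`, is not yet measured. It differs from compound 3 by isopropyl in place of methyl on an oxygen on an aromatic ring, the same change as that from compound 1 to compound 2, at the same place. Going by the values given here, because the one measured instance of this change, an at least 2.3-fold lower number from compound 1 to compound 2 (0.37 log units; beyond the scatter), lowered the number beyond the scatter, a step of similar size, a 2.0-fold lower number from compound 3 to compound 4 (0.30 log units; within the scatter), is expected from compound 3 to compound 4. Compound 4 is therefore estimated at 30 nM, expected to fall between 12 nM and 90 nM.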

Compound 4, half-maximal effective concentration: 50 nM
The estimate for compound 4 lay 1.7-fold (0.22 log units) below the measured number; the measured number falls inside the stated range.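

On the second core, the change of methyl to isopropyl on the oxygen in this assay gave a 1.2-fold lower number from compound 3 to compound 4 (0.08 log units; within the scatter) and thus no shift that can be told apart from repeat measurement. The change therefore lowered the number beyond the scatter in one instance, but not in the other, and the two instances cannot be firmly separated: the same change on two cores in this assay, an at least 2.3-fold lower number (0.37 log units; beyond the scatter) from compound 1 to compound 2 and a 1.2-fold lower number (0.08 log units; within the scatter) from compound 3 to compound 4; the limit leaves it open whether they differ. From the compounds shown here alone, the pair shows neither that the change carries over from one core to another at the same size nor that its size depends on the core, since the first step rests on a limit and its full size stays unknown: the limit of > 500 nM in this assay, at which 1 of the 4 values shown sits.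

Only methyl and isopropyl appear on that oxygen, on two cores, and both steps come from this assay alone. Going by these compounds, how a longer chain, or a chain ending in an amine or a carboxylic acid, would behave at this place remains open, as does the effect of the same change on any further core.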